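The source may hold more compounds than are shown below. What is called first, only, known or untested is meant among the compounds shown, and "the series" means these compounds.

Measured so far in an ADME assay on MT4 cells (Homo sapiens) for cytotoxicity; on this read-out higher numbers stand for lower toxicity in this test and lower numbers for higher toxicity in this test:
compound 1 `COC(=O)c1ccc(NC(=O)CSc2snnc2-c2ccc(OC)cc2)c(Br)c1` gives 195000 nM.
compound 2 `COc1ccc(-c2nnsc2SCC(=O)Nc2ccccc2Br)cc1` reaches only a limit of the test, > 286000 nM.
compound 3 `O=C(CSc1snnc1-c1ccccc1)Nc1ccccc1Br` also reaches only a limit of the test, > 307000 nM.

Compound 4 `COC(=O)c1ccc(NC(=O)CSc2snnc2-c2ccccc2)c(Br)c1` has not yet been measured. It differs from compound 3 by methoxycarbonyl in place of hydrogen on an aromatic carbon. The same change, at the same place, separates compound 2 from compound 1, (methoxycarbonyl in place of hydrogen on an aromatic carbon); there the step was an at least 1.4-fold lower number from compound 2 to compound 1 (0.16 log units; that floor lies within the scatter). The two cores differ by hydrogen in place of methoxy on an aromatic carbon, and that step was a step that the two limits leave unreadable from compound 2 to compound 3, so the core change itself cannot be sized. Compound 4 is expected to make the step of an at least 1.5-fold lower number from compound 3 to compound 4 (0.18 log units; that floor lies within the scatter), since the same change gave an at least 1.4-fold lower number from compound 2 to compound 1 (0.16 log units; that floor lies within the scatter) on the other core. Compound 4 is therefore estimated at 200000 nM, most likely between 110000 nM and 380000 nM, with a fair chance that only a limit is reported.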

Compound 4, half-maximal cytotoxic concentration: > 269000 nM
Compound 4: a limit, no number (the forecaster's own chance of this, stated with the estimate: 30%); at least 1.3-fold (0.12 log units) between middle value and limit.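

In this assay compound 4 gives > 269000 nM, which is a limit of the test and not a number. Compound 3 also gives only a limit, so the effect of adding methoxycarbonyl to this core cannot be read, and neither can the other steps that rest on two limits. For the compounds shown here, the one readable step, swapping methoxy for hydrogen with methoxycarbonyl present, is an at least 1.3-fold higher number from compound 1 to compound 4 (0.13 log units; that floor lies within the scatter), so the data neither show that the methoxycarbonyl change carries from one core to the other nor show that it fails to.

From the compounds shown here alone, it remains open whether methoxycarbonyl changes the read-out at all on either core. Also open, going by these compounds, is what a carboxylic acid or an amine at that place would give in this assay.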